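A few compounds are considered here, and "the series" means these few. Any claim that something is new, unique, unknown or untested is made for them only; others in the source may bear on it.

Compound 3 `CNCc1c(OC)cc(Oc2cccc(Nc3ccccc3)c2)cc1OC` gives in a functional assay on HCT-116 cells (Homo sapiens) for inhibition, read by MTT assay, with a stated time of 72 h (a higher number here means a weaker inhibitor, a lower number a stronger inhibitor), only a limit, > 20000 nM. Compound 1 `COc1cc(Oc2cccc(Nc3ccccc3)c2)cc(OC)c1CNCc1ccccc1` gives 4070 nM, and compound 2 `COc1ccc(CCCNCc2c(OC)cc(Oc3ccc(Nc4ccccc4)cc3)cc2OC)cc1` gives 3230 nM. Compound 3 therefore sits at the weak end of the three, where the limit of > 20000 nM in this assay, at which 1 of the 3 values shown sits, is all that is known. Compound 4 `COc1cc(Oc2cccc(Nc3ccccc3)c2)cc(OC)c1CN[C@H](C)c1ccccc1` carries 1-phenylethyl in place of methyl on an amine nitrogen. Going by the values given here, the one measured step that bears on this change runs in the opposite direction: an at least 4.9-fold higher number from compound 1 to compound 3 (0.69 log units; beyond the scatter). Reversing it, compound 4 is expected to take a step of an at least 4.4-fold lower number from compound 3 to compound 4 (0.64 log units; beyond the scatter) back toward the level of compound 1 (4070 nM). Compound 4 is estimated at 4500 nM, within 1500 nM to 15000 nM.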

Compound 4, half-maximal inhibitory concentration: > 20000 nM
Compound 4: only a limit was reported (the forecaster's own chance of this, stated with the estimate: 10%); middle value at least 4.4-fold (0.64 log units) away from the limit.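

Compound 4 gives only a limit in this assay, the same limit as compound 3: the limit of > 20000 nM in this assay, at which 2 of the 4 values shown sit.

The step between these two compounds cannot be read. The sharper finding comes from compound 1, where methyl in place of hydrogen on the saturated chain carbon bound to the amine nitrogen and the aromatic carbon gives an at least 4.9-fold higher number from compound 1 to compound 4 (0.69 log units; beyond the scatter), so the added phenyl ring alone does not hold the level of compound 1.

Going by these compounds, how the opposite configuration at the new stereocentre behaves remains open. So does the effect of an ethyl or hydroxymethyl group on that carbon.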